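Notes on a biaryl series: compound 3 to compound 4

A few compounds are considered here, and "the series" means these few. Any claim that something is new, unique, unknown or untested is made for them only; others in the source may bear on it.

Measured so far in a functional assay on K562 cells (Homo sapiens) for antiproliferative activity, read by MTT assay, with a stated time of 48 h; a higher number here means a weaker inhibitor, a lower number a stronger inhibitor:
compound 1 `COc1ccc(-c2ccc3c(c2)C(=O)C(=O)N3Cc2ccc(F)cc2)cc1`, compound 1 gives 560 nM
compound 2 `COc1ccc(-c2ccc3c(c2)C(=O)C(=O)N3Cc2cc(C)cc(C)c2)cc1`, compound 2 gives 140 nM
compound 3 `COc1ccc(CN2C(=O)C(=O)c3cc(-c4ccc(F)cc4)ccc32)cc1`, compound 3 gives 240 nM

Compound 3 stands second highest of the three numbers. Its nearest neighbour is compound 2, with a gap that lies within the scatter; its furthest is compound 1, a gap beyond the scatter, so compound 3 sits below compound 1 but cannot be ordered against compound 2.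

Within the data shown here, the only step between measured compounds that differ in one place is a 4.0-fold lower number from compound 1 to compound 2 (0.60 log units; beyond the scatter). That step changes the group on the saturated chain carbon bound to the amide-type nitrogen, not the aryl group on the shared core, so it does not bear directly on the change to compound 4 `COc1ccc(CN2C(=O)C(=O)c3cc(-c4ccc5ccccc5c4)ccc32)cc1`, which is naphthalen-2-yl in place of 4-fluorophenyl on an aromatic carbon.

Among the measured compounds shown here, with no measured step at this position, no direction can be read from the data. The expected step is therefore a 1.2-fold lower number from compound 3 to compound 4 (0.08 log units; within the scatter), that is none beyond the scatter, with a wide range on either side. Compound 4 is estimated at 200 nM, between 70 nM and 600 nM in this assay.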

Compound 4, half-maximal inhibitory concentration: 340 nM
Beside the measured number, compound 4's estimate is 1.7-fold (0.23 log units) below it, and the stated range covers the measured number.
By their numbers in this assay, from the lowest: compounds 2, 3, 4 and 1 (each within the scatter of the next, the first and the last beyond it).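

In this assay, the first step measured at this aromatic carbon is a 1.4-fold higher number from compound 3 to compound 4 (0.15 log units; within the scatter), so compound 3 and compound 4 cannot be ordered, and naphthalen-2-yl cannot be told apart from 4-fluorophenyl here. Among these compounds, exchanging one six-membered aromatic ring of carbon only for two, with the loss of the fluorine, thus produces no step beyond the scatter in this pair, whereas the one change on the saturated chain carbon, a 4.0-fold lower number from compound 1 to compound 2 (0.60 log units; beyond the scatter), does lie beyond it. This contrast rests on a single pair at each place and makes no general rule for either, and no supporting measurement is available to account for the outcome at the aromatic carbon.

As far as these compounds go, the two aryl groups compared here are both carbon-ring groups without hydrogen-bond donors or acceptors, so it remains open whether an amine or a carboxylic acid on the same aromatic carbon would also stay within the scatter of compound 3. Also open, from the compounds shown here alone, is whether naphthalen-2-yl gives a similar result when 3,5-dimethylphenyl replaces the 4-methoxyphenyl group on the saturated chain carbon.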